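The compounds below may be only part of what the source reports. "The series", "measured", "known", "first", "only" and "open" are said of these compounds alone.

Measured so far in a functional assay on A549 cells (Homo sapiens) for antiproliferative activity, read by MTT assay, with a stated time of 48 h; a lower number here means a stronger inhibitor, a higher number a weaker inhibitor:

Compound 1, `O=C(/C=C/c1ccccc1Cl)Nc1ccc2ncnc(Nc3cccc(Cl)c3)c2c1` — 4.58 ug/mL
Compound 2, `O=C(/C=C/c1ccc(Br)cc1)Nc1ccc2ncnc(Nc3cccc(Cl)c3)c2c1` — 1.86 ug/mL
Compound 3, `O=C(/C=C/c1ccccc1Br)Nc1ccc2ncnc(Nc3cccc(Cl)c3)c2c1` — 5.63 ug/mL

Compound 3 gives the highest number of the three in this assay; against compound 1 the gap is within the usual scatter, so the two cannot be told apart, while against compound 2 it is a real if modest difference, as the step of a 3.0-fold higher number from compound 2 to compound 3 (0.48 log units; beyond the scatter) shows.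

Compound 4, `COc1cccc(/C=C/C(=O)Nc2ccc3ncnc(Nc4cccc(Cl)c4)c3c2)c1`, has not yet been measured in this assay. It differs from compound 3 in one place: 3-methoxyphenyl in place of 2-bromophenyl on a double-bonded chain carbon bound to a double-bonded chain carbon. The shared core and the amide-linked chain are untouched.

Within the data shown here, two measured steps bear on the change, though neither matches it exactly. Both concern which ring the chain carries: a 2.5-fold lower number from compound 1 to compound 2 (0.39 log units; beyond the scatter) and a 3.0-fold higher number from compound 2 to compound 3 (0.48 log units; beyond the scatter). Each shows a modest shift, and both times the ring with its substituent at the 2-position gave the higher number. Among the measured compounds shown here, no methoxy-bearing compound has been measured, so the effect of that group itself is unknown here. Since the change leaves the 2-bromophenyl, a modest step toward a lower number seems more likely than a higher one, but the new group is a real unknown.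

On that basis compound 4 is expected to give about 3 ug/mL in this assay, within a range of 1.2 ug/mL to 8 ug/mL, which would mean an expected step of a 1.9-fold lower number from compound 3 to compound 4 (0.27 log units; within the scatter).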

Compound 4, half-maximal inhibitory concentration: 2.58 ug/mL
For compound 4 the middle estimate is 1.2-fold (0.07 log units) above the measured one; the range from low to high includes it.
By their numbers in this assay, from the lowest: compounds 2, 4, 1 and 3 (each within the scatter of the next, the first and the last beyond it).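

The 3-methoxyphenyl group shows that this chain carbon can carry a ring with no chloro or bromo on it and still give a clear shift in this assay (a 2.2-fold lower number from compound 3 to compound 4 (0.34 log units; beyond the scatter)). Compound 4 also cannot be told apart from either of two halogen-bearing compounds, as the steps (a 1.4-fold higher number from compound 2 to compound 4 (0.14 log units; within the scatter)) and (a 1.8-fold lower number from compound 1 to compound 4 (0.25 log units; within the scatter)) both lie within the scatter, even though those two compounds differ from each other beyond it (a 2.5-fold lower number from compound 1 to compound 2 (0.39 log units; beyond the scatter)). The change from 2-bromophenyl to 3-methoxyphenyl swaps the group and its place on the ring in one step, so this result cannot separate the contribution of the methoxy from that of losing the bromo at its original place.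

No accompanying measurement explains why the number shifts with this change. The compounds shown never place a methoxy and a bromo at the same ring position, and they leave open how a ring carrying an amine or a carboxylic acid would behave at this chain carbon.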